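Cyano for Methyl on Selenium: a Second Test

The compounds below may be only part of what the source reports. "The series", "measured", "known", "first", "only" and "open" are said of these compounds alone.

Of the compounds shown here, three have been measured in a functional assay on HepG2 cells (Homo sapiens) for inhibition, read by MTT assay, with a stated time of 48 h; on this read-out lower numbers stand for stronger inhibition and higher numbers for weaker inhibition. Compound 1 `C[Se]c1ccc(N(C)c2nc(C3CC3)nc3ccccc23)cc1` gives 32 nM in this assay. Compound 2 `COc1ccc(N(C)c2nc(C)nc3ccccc23)cc1[Se]C` gives 17 nM, and compound 3 `COc1ccc(N(C)c2nc(C)nc3ccccc23)cc1[Se]C#N` gives 59 nM. The difference between the core of compound 1 and the core of compound 2 is not broken down here. Compounds 2 and 3 differ in one place, (cyano in place of methyl on a selenium), and this change produced a 3.5-fold higher number from compound 2 to compound 3 (0.54 log units; beyond the scatter) in this assay. The values of compound 1 and compound 3 lie within the usual scatter of each other, as do those of compound 1 and compound 2, so no order is drawn among them.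

Compound 4 `CN(c1ccc([Se]C#N)cc1)c1nc(C2CC2)nc2ccccc12` has not yet been measured. It differs from compound 1 by cyano in place of methyl on a selenium, the same change as that from compound 2 to compound 3, made at a place described in the same words. Resting on the single precedent, a 3.5-fold higher number from compound 2 to compound 3 (0.54 log units; beyond the scatter), the step in this assay is expected to be a 3.3-fold higher number from compound 1 to compound 4 (0.52 log units; beyond the scatter). Compound 4 is therefore estimated at 105 nM, within a range of 45 nM to 250 nM.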

Compound 4, half-maximal inhibitory concentration: 41 nM
Beside the measured number, compound 4's estimate is 2.6-fold (0.41 log units) above it; the measured number lies below the stated range.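

In this assay, cyano in place of methyl on a selenium gave a 1.3-fold higher number from compound 1 to compound 4 (0.11 log units; within the scatter), so on the core of compound 1 the change leaves the number within the scatter. Set beside the earlier step, the same change did not carry over in size from one core to the other: the same change on two cores in this assay, a 3.5-fold higher number (0.54 log units; beyond the scatter) from compound 2 to compound 3 and a 1.3-fold higher number (0.11 log units; within the scatter) from compound 1 to compound 4, 2.7-fold (0.43 log units) apart, beyond the scatter of two such steps. This shows that, across these two pairs, the size of the step cannot be taken from one core and applied to the other, but it does not show which feature of the cores sets the size, as the difference between them is not broken down, and two pairs offer no rule for any further core.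

The compounds shown leave open how the step would run on a core that shares only part of the difference between these two. They also leave open how an ethyl or a phenyl group on the selenium would read, and whether sulfur in place of selenium would give the same picture.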